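The compounds below may be only part of what the source reports. "The series", "measured", "known", "first", "only" and "open" are said of these compounds alone.

Measured in a physicochemical assay for solubility, in phosphate buffer, at pH 6.5; a lower number here means a less soluble compound, a higher number a more soluble compound:
- compound 1 `C=C[C@@H]1C[C@]1(NC(=O)[C@@H]1C[C@@H](Oc2nccc3cc(OC)ccc23)CN1C(=O)[C@@H](NC(=O)NC(C)(C)C)C(C)(C)C)C(=O)NS(=O)(=O)C1CC1`: 13 ug/mL
- compound 2 `C=C[C@@H]1C[C@]1(NC(=O)[C@@H]1C[C@@H](Oc2nccc3cc(OC)ccc23)CN1C(=O)[C@@H](NC(=O)N[C@H](C(=O)OC)C(C)(C)C)C(C)(C)C)C(=O)NS(=O)(=O)C1CC1`: 754 ug/mL

Compound 2 holds the higher of the two numbers, well beyond the scatter from compound 1. Compound 3 `C=C[C@@H]1C[C@]1(NC(=O)[C@@H]1C[C@@H](Oc2nccc3cc(OC)ccc23)CN1C(=O)[C@@H](NC(=O)N[C@H](C(=O)OC(C)(C)C)C(C)(C)C)C(C)(C)C)C(=O)NS(=O)(=O)C1CC1` is still unmeasured and differs from compound 2 as follows: tert-butyl in place of methyl on an oxygen next to a carbonyl group. In words, this is tert-butyl in place of methyl on an oxygen next to a carbonyl group, or methoxycarbonyl to tert-butoxycarbonyl.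

Within the data shown here, no measured step covers this exact change. The nearest evidence is the large step of a 58-fold higher number from compound 1 to compound 2 (1.76 log units; beyond the scatter), which installed 1-(methoxycarbonyl)-2,2-dimethylpropyl in place of tert-butyl on an amide-type nitrogen. That step shows only that this side chain can move the number strongly. A moderate drop, smaller than that step, is expected, though its size is uncertain. The estimated change is a 3.0-fold lower number from compound 2 to compound 3 (0.48 log units; beyond the scatter). For compound 3 the expected value is 250 ug/mL, with an estimated range of 60 ug/mL to 800 ug/mL.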

Compound 3, solubility: 1 ug/mL
Compound 3: the middle estimate sits 250-fold (2.40 log units) above what was measured; the measured number lies below the stated range.
By their numbers in this assay, from the lowest: compound 3; then compound 1; then compound 2.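

In this assay, the alkyl group on the oxygen next to the carbonyl group decides the result at this position: methoxycarbonyl to tert-butoxycarbonyl gives a 750-fold lower number from compound 2 to compound 3 (2.88 log units; beyond the scatter). The side chain on the amide-type nitrogen can therefore move the number either way, since 2,2-dimethyl-1-(tert-butoxycarbonyl)propyl in place of tert-butyl gives a 13-fold lower number from compound 1 to compound 3 (1.11 log units; beyond the scatter), whereas the methyl ester counterpart gives a 58-fold higher number from compound 1 to compound 2 (1.76 log units; beyond the scatter). No supporting data are available to account for this reversal.

On these data alone, with only methyl and tert-butyl on this oxygen, it remains open whether ethyl or isopropyl esters would stay close to the methyl ester or fall towards the tert-butyl ester. As far as these compounds go, it also remains open how a free carboxylic acid or a primary amide would read in place of the ester.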